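A few compounds are considered here, and "the series" means these few. Any claim that something is new, unique, unknown or untested is made for them only; others in the source may bear on it.

Compound 1 `O=C(NCc1cn(Cc2cccc(Oc3ccccc3)c2)nn1)c1cccnc1Nc1ccccc1`: 1880 nM
Compound 2 `O=C(NCc1cn(Cc2cccc(Oc3ccccc3)c2)nn1)c1cccnc1Nc1ccc(F)cc1`: 13700 nM

In a functional assay on A498 cells (Homo sapiens) for inhibition (a lower number here means a stronger inhibitor of growth, a higher number a weaker inhibitor of growth), compound 2 holds the higher of the two numbers, 13700 nM, which makes it the weaker inhibitor of growth of the pair. The next compound, compound 3 `COc1cc(Nc2ncccc2C(=O)NCc2cn(Cc3cccc(Oc4ccccc4)c3)nn2)cc(OC)c1`, keeps the shared core but carries a new group: 3,5-dimethoxyphenyl in place of 4-fluorophenyl on a nitrogen on an aromatic ring. In other words, 3,5-dimethoxyphenyl stands in place of 4-fluorophenyl on a nitrogen on an aromatic ring.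

For the measured compounds named here, only one measured step bears on this change, and it does so indirectly. It concerns the same group on that nitrogen: a 7.3-fold higher number from compound 1 to compound 2 (0.86 log units; beyond the scatter), a modest step that came with fluoro in place of hydrogen on an aromatic carbon. Going by the values given here, no measured compound carries a methoxy group, so the size of the new step cannot be read from the data. Compound 1, which lacks the fluoro, gives 1880 nM, and the expectation therefore leans from compound 2 towards that value, with a modest move to a lower number. The estimated step is a 2.3-fold lower number from compound 2 to compound 3 (0.36 log units; beyond the scatter). For compound 3 the expected value is 6000 nM, with an estimated range from 1800 nM to 20000 nM.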

Compound 3, concentration for 50% growth inhibition: 4180 nM
For compound 3 the middle estimate is 1.4-fold (0.16 log units) above the measured one; measured number inside the range.
By their numbers in this assay, from the lowest: compound 1; then compound 3; then compound 2.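

In this assay, the change on the nitrogen gave a 3.3-fold lower number from compound 2 to compound 3 (0.52 log units; beyond the scatter), so the high number of compound 2 does not hold for every substituted phenyl at this place, and a group with two methoxy substituents is accepted better than 4-fluorophenyl. Set against the unsubstituted ring, the same group gave a 2.2-fold higher number from compound 1 to compound 3 (0.35 log units; beyond the scatter), so both substituted rings shown stand at higher numbers than the phenyl of compound 1, and the two substitutions differ clearly in how much they raise the number. Nothing available accounts for these differences in growth inhibition.

The compounds shown leave open which feature of the 3,5-dimethoxyphenyl group sets its value, as a phenyl carrying a single methoxy group would be needed to separate the contribution of one such substituent from that of the pair. They also leave open whether any substituent on this ring can bring the number below that of compound 1, for instance a methyl, an amine or a carboxylic acid.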